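Quinazolinyl thiosemicarbazide amides: chlorophenyl isomer outlook

The source may hold more compounds than are shown below. What is called first, only, known or untested is meant among the compounds shown, and "the series" means these compounds.

Measured so far:
Compound 1, `COc1cc2ncnc(NNC(=S)NC(=O)c3ccc(C(F)(F)F)cc3)c2cc1OC`: 16500 nM
Compound 2, `COc1cc2ncnc(NNC(=S)NC(=O)c3ccccc3Cl)c2cc1OC`: 10000 nM

Both compounds carry the same core and differ only in the aryl group on the carbonyl carbon. Among the measured compounds shown here, in a functional assay on GLC82 cells (Homo sapiens) for cytotoxicity, read by MTT assay, with a stated time of 72 h (on this read-out higher numbers stand for weaker inhibition and lower numbers for stronger inhibition), compound 1 gives 16500 nM and compound 2 gives 10000 nM; the only step recorded, a 1.7-fold lower number from compound 1 to compound 2 (0.22 log units; within the scatter), leaves the two compounds within the scatter of each other, so compound 2 cannot be ranked against compound 1.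

Compound 3, `COc1cc2ncnc(NNC(=S)NC(=O)c3ccc(Cl)cc3)c2cc1OC`, is not yet measured. It differs from compound 2 as follows: 4-chlorophenyl in place of 2-chlorophenyl on a carbonyl carbon. For the measured compounds named here, no measured step moves a chlorine from one position to another on this phenyl ring, so the step from compound 1 to compound 2 bears on it only loosely, as a sign that a change of the aryl substituent gave no shift beyond the scatter. For compound 3 the estimated step is a 1.2-fold higher number from compound 2 to compound 3 (0.08 log units; within the scatter), expected to stay within the scatter. Compound 3 is therefore estimated at 12000 nM, with a range from 5000 nM to 30000 nM.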

Compound 3, half-maximal inhibitory concentration: 9620 nM
Compound 3: middle estimate off by 1.2-fold (0.10 log units), on the high side; measured number inside the range.
By their numbers in this assay, from the lowest: compounds 3, 2 and 1 (each within the scatter of the next).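

Among the compounds shown here, exchanging 2-chlorophenyl for 4-chlorophenyl on the carbonyl carbon gives a 1.0-fold lower number from compound 2 to compound 3 (0.02 log units; within the scatter) in this assay and is the first direct test of where the chlorine sits on this ring; the two isomers cannot be told apart here. Chloro in place of trifluoromethyl on an aromatic carbon gives a 1.7-fold lower number from compound 1 to compound 3 (0.23 log units; within the scatter) and so also cannot be resolved, which leaves compound 1, compound 2 and compound 3 unranked. No supporting data bear on these results or offer an explanation for them.

As far as these compounds go, whether an amine or a carboxylic acid on this phenyl ring, or a longer alkyl chain in place of the ring, would give a number beyond the scatter of these three remains open. Also open, from the compounds shown here alone, is how much the shared core contributes, as it stays the same throughout these compounds.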